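Acylating the amine of compound 1: an untested step

The compounds below may be only part of what the source reports. "The series", "measured", "known", "first", "only" and "open" are said of these compounds alone.

Measured compounds:
Compound 1 `COc1ccc(-c2nc(N)c3nn(-c4ccccc4)cc3n2)cc1`: 33%
Compound 2 `COc1ccc(-c2nc(N)c3nn(-c4ccc(OC)cc4)cc3n2)cc1`: 1%
Compound 3 `Nc1nc(-c2ccc(O)cc2)nc2cn(-c3ccccc3)nc12`: 31%

In an assay on CHO cells for displacement of a labelled ligand from adenosine receptor A1 (Homo sapiens), read by scintillation counting, with a stated time of 120 min, tested at 1 uM (a lower number here means less inhibition, a higher number more inhibition at the concentration tested (going by the name of the read-out)), compound 1 gives the highest of the three numbers. Compound 3 sits a number 2 percentage points lower from compound 1 to compound 3 (within the scatter), so the two are not distinguishable. Compound 2 lies a number 32 percentage points lower from compound 1 to compound 2 (beyond the scatter), a change that came from methoxy in place of hydrogen on an aromatic carbon.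

Compound 4 `COc1ccc(-c2nc(NC(=O)c3ccccc3)c3nn(-c4ccccc4)cc3n2)cc1` is not yet measured. It differs from compound 1 in one place: benzoyl in place of hydrogen on a nitrogen on an aromatic ring.

Neither measured step touches this nitrogen: the step from compound 1 to compound 2 alters a different aromatic ring, and the step from compound 1 to compound 3 alters an oxygen. The data therefore give no direct guide to the effect of a benzoyl group here. With compound 1 as the only anchor, the estimate for compound 4 in this assay is 25%, within 0% to 60%, which is expected to mean a number 8 percentage points lower from compound 1 to compound 4 (within the scatter), a change that may well stay within the scatter but is highly uncertain.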

Compound 4, a percentage reported as inhibition, at one concentration (the size of the read-out at that concentration, not a potency): 2%
For compound 4 the middle estimate is 23 percentage points above the measured one; the measured number falls inside the stated range.
By their numbers in this assay, from the lowest: compounds 2 and 4 (each within the scatter of the next); then compounds 3 and 1 (each within the scatter of the next).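

Turning the amino group of compound 1 into benzamido gives a number 31 percentage points lower from compound 1 to compound 4 (beyond the scatter) in this assay, so this nitrogen, which neither earlier step touched, is a place where a change can strongly alter the read-out. Among these compounds, it is also the second place on compound 1 where adding a group lowers the number, after the methoxy step that gave a number 32 percentage points lower from compound 1 to compound 2 (beyond the scatter), whereas the only step that removes atoms, hydrogen in place of methyl on the oxygen, stays within the scatter. Nothing available explains why the benzoyl group has this effect.

The compounds shown leave open whether a smaller acetyl group or a plain methyl on this nitrogen would lower the number as well. They also leave open whether a benzyl group, which keeps the aromatic ring but has no carbonyl, would do the same.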